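A Fluoro Gives Way to Hydrogen on Compound 2

The compounds below may be only part of what the source reports. "The series", "measured", "known", "first", "only" and "open" are said of these compounds alone.

In a physicochemical assay for solubility, read by nephelometry, in phosphate buffer, measured as kinetic solubility, with a stated time of 30 min, at pH 6.5 (on this read-out higher numbers stand for higher solubility and lower numbers for lower solubility), compound 1 `COc1cc(-c2cc(-c3ccc(S(C)(=O)=O)cc3)cnc2N)ccc1O` gives 6.3 ug/mL, while compound 2 `CS(=O)(=O)c1ccc(-c2cnc(N)c(-c3ccc(C(F)(F)F)c(F)c3)c2)cc1` gives 1.6 ug/mL. Compound 2 thus has the lower of the two numbers, and the gap lies beyond the scatter. Compound 3 `CS(=O)(=O)c1ccc(-c2cnc(N)c(-c3ccc(C(F)(F)F)cc3)c2)cc1` differs from compound 2 in one place: hydrogen in place of fluoro on an aromatic carbon. Going by the values given here, no measured pair shows this change, so in this assay no step beyond the scatter is expected. The estimate is a 1.3-fold higher number from compound 2 to compound 3 (0.10 log units; within the scatter). For compound 3 the expected value is 2 ug/mL, with an estimated range from 0.9 ug/mL to 4.5 ug/mL.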

Compound 3, solubility: < 1.6 ug/mL
Compound 3: no number, only a limit; the forecaster's own chance of this, stated with the estimate: 10%; at least 1.2-fold (0.09 log units) between middle value and limit.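

In this assay, compound 3 gives < 1.6 ug/mL, which is a limit and not a number. Hydrogen in place of fluoro, on the aromatic carbon ortho to a trifluoromethyl group, is the only one-place change shown, and it gives a number no higher from compound 2 to compound 3 (the limit leaves the size open). Taking away this fluoro therefore brought no rise on this read-out, though the size of the step cannot be read: the limit of < 1.6 ug/mL in this assay, at which 1 of the 3 values shown sits.

The compounds shown leave open what an amine or a carboxylic acid at this position would give in this assay. They also leave open what replacing the trifluoromethyl group itself would give.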